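Swapping the Pyridine on the Core Nitrogen of Compound 2

The source may report more compounds than this note shows. Statements on the series, on what has been measured and on what is new or still open speak of the compounds shown alone.

Among the compounds with values here, compound 2 `CC(C)OC(=O)N1CCC(Oc2ncnc3c2CCN3c2ccc(S(C)(=O)=O)cn2)CC1` holds the lower of the two numbers measured so far. In a functional assay on CHO-K1 cells for agonist activity at Glucose-dependent insulinotropic receptor (Homo sapiens), read by a luciferase reporter, with a stated time of 5 h (a higher number here means that more compound is needed for the effect, a lower number that less compound is needed), compound 2 gives 126 nM, whereas compound 1 `N#CN1CCC(O)CC1` gives 316 nM in this assay, a gap that lies beyond the scatter. Compound 3 `CC(C)OC(=O)N1CCC(Oc2ncnc3c2CCN3c2ccc([S+]([O-])N(C)C)cc2)CC1` has not yet been measured. It differs from compound 2 in one place: a group of 11 heavy atoms (8 carbon, 1 nitrogen, 1 oxygen, 1 sulfur; one six-membered aromatic ring of carbon only) in place of a group of 10 heavy atoms (6 carbon, 1 nitrogen, 2 oxygen, 1 sulfur; one six-membered aromatic ring with 1 hetero atom), on a nitrogen on an aromatic ring in a ring. Within the data shown here, no step between measured compounds shows what such a change does here, so the expectation rests on compound 2 alone, whose value in this assay is 126 nM. The step from compound 2 to compound 3 is expected to be small, toward a higher number, and possibly not beyond the scatter: a 1.7-fold higher number from compound 2 to compound 3 (0.24 log units; within the scatter). For compound 3 the estimate in this assay is 220 nM, with a range from 60 nM to 800 nM.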

Compound 3, half-maximal effective concentration: 501 nM
The estimate for compound 3 lay 2.3-fold (0.36 log units) below the measured number; low and high end bracket the measured number.
By their numbers in this assay, from the lowest: compound 2; then compounds 1 and 3 (each within the scatter of the next).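

In this assay the first step read at this place, on a nitrogen on an aromatic ring in a ring, is a 4.0-fold higher number from compound 2 to compound 3 (0.60 log units; beyond the scatter) and lies beyond the scatter, so the number here does respond to what is attached at this nitrogen. The entering group differs from 5-(methylsulfonyl)pyridin-2-yl in two respects at once, in its six-membered aromatic ring of carbon only and in its sulfur-bearing substituent, and this one step cannot separate the two. Nothing measured on hand explains the rise.

Which of the two differences carries the step stays open, as a phenyl ring bearing methylsulfonyl would be needed to tell them apart. As far as these compounds go, what an amine, a nitrile or a carboxylic acid would do on this ring also remains unknown.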